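Terminal group exchange on two chain lengths, rat stomach series

This account rests on a few compounds, and the source may have more. Where it says the series, first, only, none or still open, it means among the compounds named here.

Compound 1 `CC/N=C(/NC#N)NCCCn1nc(-c2ccccc2)ccc1=O` and compound 2 `CN(C)/C(=N/CCCn1nc(-c2ccccc2)ccc1=O)NC#N` share one core; compound 3 `CC/N=C(/NC#N)NCCCCCn1nc(-c2ccccc2)ccc1=O` has another, and the difference between the two cores is not broken down here. In a functional assay on the whole organism (stomach) with Rattus norvegicus as the target (on this read-out higher numbers stand for an effect only at larger amounts of compound and lower numbers for an effect already at smaller amounts), compound 1 gives 78.3 mg/kg and compound 2 gives 53 mg/kg; the change a group of 8 heavy atoms (4 carbon, 4 nitrogen; no ring) in place of a group of 8 heavy atoms (4 carbon, 4 nitrogen; no ring), on a saturated chain carbon, three bonds along the chain from an aromatic nitrogen brought a 1.5-fold lower number from compound 1 to compound 2 (0.17 log units; within the scatter). In this assay compound 3 gives 100 mg/kg. Compound 4 `CN(C)/C(=N/CCCCCn1nc(-c2ccccc2)ccc1=O)NC#N` is not yet measured and arises from compound 3 by a group of 8 heavy atoms (4 carbon, 4 nitrogen; no ring) in place of a group of 8 heavy atoms (4 carbon, 4 nitrogen; no ring), on a saturated chain carbon, five bonds along the chain from an aromatic nitrogen, the same kind of change, here on a saturated chain carbon five bonds along the chain from an aromatic nitrogen rather than three bonds. Going by the values given here, for compound 4 the expected step is a 1.5-fold lower number from compound 3 to compound 4 (0.17 log units; within the scatter), because a 1.5-fold lower number from compound 1 to compound 2 (0.17 log units; within the scatter) lay within the scatter and no other pair shows this exchange. For compound 4 in this assay the estimated value is 68 mg/kg, expected between 35 mg/kg and 135 mg/kg.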

Compound 4, dose for half-maximal effect: 81.5 mg/kg
For compound 4 the middle estimate is 1.2-fold (0.08 log units) below the measured one; the measured number falls inside the stated range.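

In this assay the exchange gives a 1.2-fold lower number from compound 3 to compound 4 (0.09 log units; within the scatter), and the two cores show no readable difference in how they take it: the same change on two cores in this assay, a 1.5-fold lower number (0.17 log units; within the scatter) from compound 1 to compound 2 and a 1.2-fold lower number (0.09 log units; within the scatter) from compound 3 to compound 4, 1.2-fold (0.08 log units) apart, within the scatter of two such steps

Going by these compounds alone, both steps lie within the scatter, so the agreement shows only that the exchange stays small on each core, not that a real effect of fixed size carries from one core to the other. Two pairs in a single read-out also say nothing about cores outside this set.

Open, as far as these compounds go, is whether a primary amine or a carboxylic acid in place of the terminal group would move the number beyond the scatter. Also open, from the compounds shown here alone, is how the same exchange behaves on a heptyl chain.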